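A few compounds are considered here, and "the series" means these few. Any claim that something is new, unique, unknown or untested is made for them only; others in the source may bear on it.

Working notes on the series.

Two compounds carry numbers in a functional assay on Jurkat cells (Homo sapiens) for inhibition, read by MTT assay, with a stated time of 72 h; a higher number here means a weaker inhibitor of growth, a lower number a stronger inhibitor of growth. Compound 1 `COC(=O)c1nc(C)n(-c2ccc(Cl)cc2)n1` gives 65900 nM in this assay. Compound 2 `CCc1nc(C(=O)OC)nn1-c1ccc(F)cc1` gives 11000 nM in this assay. Compound 2 thus stands with the lowest of the two numbers; its nearest neighbour is compound 1, whose number is higher by a gap that lies beyond the scatter. Among the compounds with values here, the two differ in more than one place, so no single step between them is counted; their two values only show that the pair with the ethyl group and the fluoro-substituted aryl sits at the lower number.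

Compound 3 `COC(=O)c1nc(C2CCCC2)n(-c2ccc(F)cc2)n1` has not been measured. It differs from compound 2 by cyclopentyl in place of ethyl on an aromatic carbon. Within the data shown here, with no counted step of a matching kind in hand, the expectation rests on compound 2 alone, whose value of 11000 nM marks the starting point. A modest move toward a lower number is expected for compound 3, of size a 2.2-fold lower number from compound 2 to compound 3 (0.34 log units; beyond the scatter), but a step within the scatter cannot be ruled out. Compound 3 is therefore estimated at 5000 nM in this assay, with a range from 1500 nM to 20000 nM.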

Compound 3, concentration for 50% growth inhibition: 9550 nM
Compound 3: middle estimate off by 1.9-fold (0.28 log units), on the low side; the measured number falls inside the stated range.
By their numbers in this assay, from the lowest: compounds 3 and 2 (each within the scatter of the next); then compound 1.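

Cyclopentyl in place of ethyl on this aromatic carbon, between two ring nitrogen atoms, gives the first counted step of the series in this assay: a 1.2-fold lower number from compound 2 to compound 3 (0.06 log units; within the scatter). The values of the two compounds cannot be told apart, so this position holds either ethyl or cyclopentyl, with 2 and 5 heavy atoms and the second bringing a five-membered non-aromatic ring, without a difference that this assay resolves; the earlier pair, differing in more than one place, could not show this for any single position. Nothing at hand explains this result.

The compounds shown leave open whether a group of another kind on this carbon, such as an amine or a carboxylic acid, or a longer chain such as hexyl, would separate from ethyl and cyclopentyl. Within the data shown here, they also leave open how much of the gap between compound 1 and compound 2 belongs to the group on this carbon and how much to the substituent on the aryl ring, since no single-place step connects compound 1 to the others.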